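Moving the group from a triazole to an acyl sulfonamide

This account rests on a few compounds, and the source may have more. Where it says the series, first, only, none or still open, it means among the compounds named here.

Measured compounds:
- Compound 1, `CS(=O)(=O)c1nnc(-c2cc(F)c(COc3ccc(Cl)c(Cl)c3)cc2F)[nH]1`: 4.8
- Compound 2, `O=C(O)c1cc(F)c(COc2ccc(Cl)c(Cl)c2)cc1F`: 3.1
- Compound 3, `CC(=O)NS(=O)(=O)c1cc(F)c(COc2ccc(Cl)c(Cl)c2)cc1F`: 3.7

These three compounds share a common core and differ only in the group attached to one aromatic carbon. In a physicochemical assay for acid dissociation, read by capillary electrophoresis, compound 1 stands highest of the three: its nearest neighbour is compound 3, a step of a number 1.10 log units lower from compound 1 to compound 3 (beyond the scatter), and the furthest is compound 2, a step of a number 1.70 log units lower from compound 1 to compound 2 (beyond the scatter). Between those two, the step of a number 0.60 log units higher from compound 2 to compound 3 (beyond the scatter) is modest.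

Compound 4, `CS(=O)(=O)NC(=O)c1cc(F)c(COc2ccc(Cl)c(Cl)c2)cc1F`, has not yet been measured. Its structure differs from compound 1 as follows: (methylsulfonyl)carbamoyl in place of 5-(methylsulfonyl)-4H-1,2,4-triazol-3-yl on an aromatic carbon. The incoming group is a chain built from a carbonyl, an amide hydrogen and a methylsulfonyl group, so it resembles the acetylsulfamoyl group of compound 3 with the carbonyl and the sulfonyl in exchanged order, and it sits on the same aromatic carbon.

Going by the values given here, the steps that bear on this change are the two departures from compound 1, a number 1.70 log units lower from compound 1 to compound 2 (beyond the scatter) and a number 1.10 log units lower from compound 1 to compound 3 (beyond the scatter), both large and both downward. Replacing the triazole with the (methylsulfonyl)carbamoyl chain is therefore expected to lower the number in this assay, by a step near a number 0.70 log units lower from compound 1 to compound 4 (beyond the scatter), rather than leave it within the scatter. For compound 4 the estimate is 4.1, within a range from 3.6 to 4.6.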

Compound 4, acid dissociation constant: 3.1
Estimate against measurement, compound 4: 1.00 log units above; the whole stated range lies above it.
By their numbers in this assay, from the lowest: compounds 2 and 4 (each within the scatter of the next); then compound 3; then compound 1.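

In this assay, the (methylsulfonyl)carbamoyl group on this aromatic carbon gives a large drop from the triazole (a number 1.70 log units lower from compound 1 to compound 4 (beyond the scatter)), while methanesulfonamido in place of hydroxy on the carbonyl carbon leaves the carboxy result in place (no change at the digits printed from compound 2 to compound 4 (within the scatter)). The two acyl sulfonamide chains are not interchangeable here: with the carbonyl and the sulfonyl in exchanged order, the aromatic carbon carrying the carbonyl rather than the sulfur, the reading shifts by a modest but real amount (a number 0.60 log units lower from compound 3 to compound 4 (beyond the scatter)). Nothing in the data shown accounts for these steps.

The compounds shown leave open whether a larger group in place of the methylsulfonyl, such as ethylsulfonyl or phenylsulfonyl, would keep the reading of the (methylsulfonyl)carbamoyl chain, and where a tetrazole on the same aromatic carbon would fall among these groups. They also leave open how much the two fluoro groups matter to these steps, since every compound here carries both and none has hydrogen in their place.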